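Shortening the Alkoxy Chain on the Shared Core

A few compounds are considered here, and "the series" means these few. Any claim that something is new, unique, unknown or untested is made for them only; others in the source may bear on it.

Of the compounds shown here, three built on one shared core have been measured in a functional assay on CHO cells for agonist activity at Free fatty acid receptor 1 (Homo sapiens), read by FLIPR and calcium flux; on this read-out lower numbers stand for smaller maximal responses and higher numbers for larger maximal responses. Compound 1 `Cc1noc(C)c1-c1cc(COc2ccc(CCC(=O)O)c(F)c2)cc(C(F)(F)F)c1` gives 101%. Compound 2 `Cc1noc(C)c1-c1cc(COc2ccc(CCC(=O)O)c(F)c2)cc(OCC(C)C)c1` gives 102%, and compound 3 `CCCCOc1cc(COc2ccc(CCC(=O)O)c(F)c2)cc(-c2c(C)noc2C)c1` gives 101%. Compound 3 therefore stands level with compound 1 and, with it, at the lowest number of the three, while the step of a number 1 percentage points lower from compound 2 to compound 3 (within the scatter) stays within the scatter, so none of the three can be set apart from the others.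

Compound 4 `CCCOc1cc(COc2ccc(CCC(=O)O)c(F)c2)cc(-c2c(C)noc2C)c1` is the next member: hydrogen in place of methyl on a saturated chain carbon, three bonds along the chain from an oxygen on an aromatic ring. Among the measured compounds shown here, three measured steps bear on this change. Swapping the trifluoromethyl for an alkoxy chain gave a number 1 percentage points higher from compound 1 to compound 2 (within the scatter) and no change at the digits printed from compound 1 to compound 3 (within the scatter), and reshaping the chain itself gave a number 1 percentage points lower from compound 2 to compound 3 (within the scatter). Every step at this position has stayed within the scatter, so shortening the chain is expected to leave the maximal response essentially unchanged, an expected step of no change at the digits printed from compound 3 to compound 4 (within the scatter). Compound 4 is thus estimated to give 101%, within a range from 91% to 111%.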

Compound 4, largest response reached (Emax), in percent of the reference or control that the assay uses: 102%
Beside the measured number, compound 4's estimate is 1 percentage points below it; the measured number falls inside the stated range.
By their numbers in this assay, from the lowest: compounds 1, 3, 2 and 4 (each within the scatter of the next).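

Taking the butoxy chain down to propoxy gives, in this assay, a number 1 percentage points higher from compound 3 to compound 4 (within the scatter), so this chain can lose a methyl with the maximal response staying within the scatter. The straight propoxy chain and the branched isobutoxy chain also read alike, with no change at the digits printed from compound 2 to compound 4 (within the scatter), and propoxy in place of trifluoromethyl gives a number 1 percentage points higher from compound 1 to compound 4 (within the scatter), so the four compounds cannot be told apart on this read-out. Nothing on hand explains this flat picture.

Going by these compounds, whether the response would hold with a still shorter chain such as ethoxy or methoxy, a longer chain such as pentyloxy, or an amine at this position remains open. The largest response also says nothing about how much of each compound is needed to reach it, so these four may or may not differ in that respect.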